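A few compounds are considered here, and "the series" means these few. Any claim that something is new, unique, unknown or untested is made for them only; others in the source may bear on it.

Measured set, an assay on HeLa cells with Bile acid receptor (Homo sapiens) as the target, read by a luciferase reporter, with a stated time of 24 h; on this read-out higher numbers stand for an effect only at larger amounts of compound and lower numbers for an effect already at smaller amounts:
compound 1 `CC(C)(C)c1ccc(C(=O)NCc2ccc(NC(=O)C(F)(F)F)cc2Cl)cc1` — 14 nM
compound 2 `CC(C)(C)c1ccc(C(=O)NCc2ccc(OC(F)(F)F)cc2)cc1` — 160 nM
compound 3 `CC(NC(=O)c1ccc(C(C)(C)C)cc1)c1ccc(C(=O)O)cc1` — 76 nM

Compound 2 sits at the highest of the three numbers in this assay. Its nearest neighbour is compound 3, whose number is lower by a margin beyond the usual scatter, and the gap to compound 1 is larger still. All three share the same tert-butyl benzamide portion; they differ in what the benzylic side carries.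

Compound 4 `CC(C)(C)c1ccc(C(=O)NCc2ccc(OCC(=O)O)cc2)cc1` is the next entry, not yet measured. Relative to compound 2 the change is carboxymethyl in place of trifluoromethyl on an oxygen on an aromatic ring, so the trifluoromethoxy substituent of compound 2 becomes a carboxymethoxy substituent. Within the data shown here, no measured pair in this set isolates that single change, so the expected size of the step rests on the wider set only. A carboxylic acid is present in compound 3, and because compound 3 gives 76 nM, an acid on the benzylic side appears compatible with a number below that of compound 2. The expected step from compound 2 to compound 4 in this assay is therefore a modest one toward lower numbers, a 1.5-fold lower number from compound 2 to compound 4 (0.16 log units; within the scatter), though a step within the scatter remains plausible. Compound 4 is thus expected to give about 110 nM, in a range from 35 nM to 400 nM.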

Compound 4, half-maximal effective concentration: 730 nM
Compound 4: the middle estimate sits 6.6-fold (0.82 log units) below what was measured; the measured number lies above the stated range.
By their numbers in this assay, from the lowest: compound 1; then compound 3; then compound 2; then compound 4.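

In this assay, among these compounds, the exchange of trifluoromethyl for carboxymethyl on an oxygen on an aromatic ring gives a 4.6-fold higher number from compound 2 to compound 4 (0.66 log units; beyond the scatter) and this is the first step that isolates a change in one place. The position therefore does not take this exchange without cost: with the rest of the structure held constant, carboxymethoxy in place of trifluoromethoxy shifts the effect to larger amounts of compound, by a margin beyond the usual scatter. No supporting measurement bears on what lies behind this shift.

As far as these compounds go, whether the shift follows the carboxylic acid itself or the chain that carries it stays open. A methyl ester or a primary amide in place of the acid, or a longer chain ending in a carboxylic acid on the same oxygen, would help separate the two.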